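Trimming a Benzyl Group Down to Methyl

A few compounds are considered here, and "the series" means these few. Any claim that something is new, unique, unknown or untested is made for them only; others in the source may bear on it.

Measured compounds:
compound 1 `C=C1C(=O)O[C@H]2[C@H]1CC/C(COC(=O)Cn1cc(F)c(=O)n(Cc3ccc(Cl)cc3)c1=O)=C\CC[C@@]1(C)O[C@@H]21`: 2420 nM
compound 2 `C=C1C(=O)O[C@H]2[C@H]1CC/C(COC(=O)Cn1cc(F)c(=O)n(Cc3ccc(F)cc3F)c1=O)=C\CC[C@@]1(C)O[C@@H]21`: 5010 nM

For the measured compounds named here, in a functional assay on Bel7402/5-FU cells (Homo sapiens) for antiproliferative activity, read by MTT assay, with a stated time of 72 h (on this read-out higher numbers stand for weaker inhibition and lower numbers for stronger inhibition), compound 2 gives 5010 nM, the higher of the two numbers; its only neighbour, compound 1, gives 2420 nM, and the step of a 2.1-fold higher number from compound 1 to compound 2 (0.32 log units; beyond the scatter) is the single comparison available. Compound 3 `C=C1C(=O)O[C@H]2[C@H]1CC/C(COC(=O)Cn1cc(F)c(=O)n(C)c1=O)=C\CC[C@@]1(C)O[C@@H]21` differs from compound 2 by hydrogen in place of 2,4-difluorophenyl on a saturated chain carbon bound to an aromatic nitrogen. Going by the values given here, the one measured step exchanged one aryl group for another and shifted the number modestly; no measured step removes the aryl group altogether, so that step offers only weak guidance here. With the whole ring gone, a further rise in the number, meaning weaker inhibition, seems the more likely outcome, though its size is uncertain. Compound 3 is therefore expected to give 7000 nM (range 2500 nM to 20000 nM) in this assay, an expected step of a 1.4-fold higher number from compound 2 to compound 3 (0.15 log units; within the scatter).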

Compound 3, half-maximal inhibitory concentration: 11700 nM
For compound 3 the middle estimate is 1.7-fold (0.22 log units) below the measured one, within the range that was stated.
By their numbers in this assay, from the lowest: compound 1; then compound 2; then compound 3.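

Methyl in place of 2,4-difluorobenzyl weakens inhibition in this assay (a 2.3-fold higher number from compound 2 to compound 3 (0.37 log units; beyond the scatter)). Methyl in place of the 4-chlorobenzyl group gives a similar direction of change (a 4.8-fold higher number from compound 1 to compound 3 (0.68 log units; beyond the scatter)). Both ring-bearing compounds therefore give lower numbers than compound 3, so among these three an aromatic ring on this saturated chain carbon goes with stronger inhibition, which the earlier swap of one ring for another could not reveal. No accompanying measurement explains why the number rises when the ring is lost.

As far as these compounds go, whether a plain benzyl group with no halogen on its ring would keep the lower numbers remains open. Also open, from the compounds shown here alone, is whether a longer chain such as butyl, with no ring at all, or a benzyl ring carrying an amine would do as well.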